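The source may hold more compounds than are shown below. What is called first, only, known or untested is meant among the compounds shown, and "the series" means these compounds.

Measured in a physicochemical assay for solubility, read by HPLC, in simulated intestinal fluid, with a stated time of 16 h, tested at 125 ug/mL; a higher number here means a more soluble compound, a lower number a less soluble compound:
- compound 1 `CNC(=O)c1cc(C(=O)NC2CC2)cn(Cc2ccc(OC)cc2)c1=O`: 263 ug/mL
- compound 2 `CNC(=O)c1cc(C(=O)NC2CC2)cn(Cc2ccc(F)cc2)c1=O`: 84 ug/mL
- compound 3 `CNC(=O)c1cc(C(=O)NC2CC2)cn(Cc2cccc(F)c2)c1=O`: 31 ug/mL

For the measured compounds named here, of these three numbers, the one for compound 3 is the lowest, at 31 ug/mL. Compound 2 is its nearest neighbour and compound 1 lies furthest away.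

The next compound is compound 4 `CNC(=O)c1cc(C(=O)NC2CC2)cn(Cc2cccc3[nH]ccc23)c1=O`. The change is 1H-indol-4-yl in place of 3-fluorophenyl on a saturated chain carbon bound to an aromatic nitrogen: 1H-indol-4-yl in place of 3-fluorophenyl, on a saturated chain carbon bound to an aromatic nitrogen.

The most relevant measured steps changed the aromatic group at this same place. They are a 2.7-fold lower number from compound 2 to compound 3 (0.43 log units; beyond the scatter) and an 8.5-fold lower number from compound 1 to compound 3 (0.93 log units; beyond the scatter). A third step, a 3.1-fold lower number from compound 1 to compound 2 (0.50 log units; beyond the scatter), also shows that this part of the molecule can shift the number. All three are modest, but none involves 1H-indol-4-yl, so they suggest a possible size and give no firm direction.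

Going by the values given here, with compound 3 already lowest at 31 ug/mL, and no measured compound carrying the new group, no clear move beyond the scatter is expected in this assay. The estimate is a 1.3-fold higher number from compound 3 to compound 4 (0.11 log units; within the scatter), a small expected change that leaves room for a modest move either way. For compound 4, the expected value is 40 ug/mL, with an estimated range from 12 ug/mL to 130 ug/mL.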

Compound 4, solubility: 17 ug/mL
For compound 4 the middle estimate is 2.4-fold (0.37 log units) above the measured one, and the stated range covers the measured number.
By their numbers in this assay, from the lowest: compounds 4 and 3 (each within the scatter of the next); then compound 2; then compound 1.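

In this assay, putting the two-ring 1H-indol-4-yl in place of the single-ring 3-fluorophenyl on the saturated chain carbon bound to an aromatic nitrogen gives a 1.8-fold lower number from compound 3 to compound 4 (0.26 log units; within the scatter), so this larger group, which also brings a hydrogen-bond donor, cannot be told apart from 3-fluorophenyl here. For the compounds shown here, measured against the other two groups at this place, the same new group gives a 4.9-fold lower number from compound 2 to compound 4 (0.69 log units; beyond the scatter) and a 15-fold lower number from compound 1 to compound 4 (1.19 log units; beyond the scatter), and the second of these is the first large step, which widens the span seen at this one position. Nothing available gives a measured reason for these numbers.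

The compounds shown leave open whether the hydrogen on the indole nitrogen has any bearing on the number, since no matching group without that hydrogen, such as an N-methylindole, appears among them. They also leave open how far the number would move with an amine or a carboxylic acid on the aromatic ring, or with a pyridine ring in place of the benzene ring.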